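The source may hold more compounds than are shown below. What is called first, only, known or untested is meant among the compounds shown, and "the series" means these compounds.

Working notes on the series. Three compounds have numbers in a functional assay on SK-N-AS cells (Homo sapiens) for antiproliferative activity, with a stated time of 72 h; a higher number here means a weaker inhibitor, a lower number a stronger inhibitor: compound 1 (`Cc1cc(C)cc(C(=O)N(CCC(=O)NCc2ccccc2)Cc2ccc(C(=O)NO)cc2)c1`), compound 2 (`Cc1ccc(CNC(=O)CCN(Cc2ccc(C(=O)NO)cc2)C(=O)c2ccc(N(C)C)cc2)cc1`) and compound 3 (`Cc1ccc(NC(=O)CCN(Cc2ccc(C(=O)NO)cc2)C(=O)c2ccccc2)cc1`). Compound 2 gives 340 nM and compound 3 gives 620 nM, two values within the scatter of each other, so compound 2 shares the strong end of this small set with compound 3. Compound 1 gives 1860 nM, a higher number than that of compound 2 and beyond the scatter.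

For the measured compounds named here, compound 4 (`CN(C)c1ccc(C(=O)N(CCC(=O)NCc2ccccc2)Cc2ccc(C(=O)NO)cc2)cc1`) has no measurement yet. Relative to compound 2 it has hydrogen in place of methyl on an aromatic carbon, which turns 4-methylbenzyl into benzyl (hydrogen in place of methyl on an aromatic carbon).

Going by the values given here, no measured pair isolates this change. Compound 1 also carries the benzyl group, but it differs from compound 4 elsewhere too, so its value says little about the methyl alone. The end bearing the methyl does vary between compound 2 at 340 nM and compound 3 at 620 nM, though these two also differ in more than one place, and their values stay within the scatter.

In this assay, a small move towards a higher number is expected, with no change beyond the scatter, and the estimated step is a 1.3-fold higher number from compound 2 to compound 4 (0.12 log units; within the scatter). For compound 4 the estimate is 450 nM, with an expected range of 200 nM to 1000 nM.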

Compound 4, half-maximal inhibitory concentration: 1420 nM
Compound 4: middle estimate off by 3.2-fold (0.50 log units), on the low side; the whole stated range lies below it.
By their numbers in this assay, from the lowest: compounds 2 and 3 (each within the scatter of the next); then compounds 4 and 1 (each within the scatter of the next).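

In this assay, for the compounds shown here, hydrogen in place of methyl on the aromatic carbon gives a 4.2-fold higher number from compound 2 to compound 4 (0.62 log units; beyond the scatter) and so provides the first comparison that isolates this position: in this pair, the methyl of the 4-methylbenzyl group counts for more than the scatter, which the earlier compounds, differing in more than one place, could not show. With benzyl held constant, 4-(dimethylamino)phenyl in place of 3,5-dimethylphenyl on the carbonyl carbon gives a 1.3-fold lower number from compound 1 to compound 4 (0.12 log units; within the scatter) and stays within the scatter, so this pair does not separate those two groups. The compounds offer no measured basis for explaining the size of the methyl step.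

Whether the methyl is specific at this place remains open, as the series shown has no ethyl, methoxy or chlorine there to compare with methyl and hydrogen. Also open is whether the step carries over to another carbonyl-side group, since the pair with and without the methyl exists only with 4-(dimethylamino)phenyl, and a 4-methylbenzyl partner for the 3,5-dimethylphenyl compound 1 is absent from the compounds shown.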